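Replacing the cyano of compound 3 with an aryl sulfanyl group

A few compounds are considered here, and "the series" means these few. Any claim that something is new, unique, unknown or untested is made for them only; others in the source may bear on it.

Measured so far in an ADME assay on HEL cells (Homo sapiens) for cytotoxicity, with a stated time of 3 days; on this read-out higher numbers stand for lower toxicity in this test and lower numbers for higher toxicity in this test:
compound 1, `Cc1cc(-n2cccc2)c2ncc(CSCCc3ccccc3)n2c1`: 100 ug/mL
compound 2, `Cc1cc(-n2ccc3ccccc32)c2ncc(CSCCc3ccccc3)n2c1`: 100 ug/mL
compound 3, `Cc1cc(C#N)c2ncc(CSCCc3ccccc3)n2c1`: >= 20 ug/mL

Compound 1 and compound 2 carry a five-membered nitrogen heterocycle on the shared core, and the exchange of one for the other gives no change at the digits printed from compound 1 to compound 2 (within the scatter) in this assay. The value of compound 3 is a limit of this assay and not a number, as noted in the limit of >= 20 ug/mL in this assay, at which 1 of the 3 values shown sits. For that reason the steps a step that the limit leaves unreadable from compound 1 to compound 3 and a step that the limit leaves unreadable from compound 2 to compound 3 cannot be sized, and compound 3 stands only as a limit on the numbers shown.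

Compound 4, `Cc1cc(Sc2ccc(O)cc2)c2ncc(CSCCc3ccccc3)n2c1`, differs from compound 3 by (4-hydroxyphenyl)sulfanyl in place of cyano on an aromatic carbon. Going by the values given here, no measured step bears directly on this exchange: the two steps that reach compound 3 are unreadable, and the one readable step, no change at the digits printed from compound 1 to compound 2 (within the scatter), concerns a change elsewhere in kind. What can be used is that compound 1 and compound 2, each bearing an aromatic substituent at this carbon, share the same value in this assay. Compound 4 also bears an aromatic substituent there, so its value is expected near theirs, with the step that the limit leaves unreadable from compound 3 to compound 4 left open in direction by the limit of compound 3. Compound 4 is therefore estimated at 70 ug/mL in this assay, in a range from 20 ug/mL to 100 ug/mL.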

Compound 4, minimum cytotoxic concentration: > 100 ug/mL
Compound 4: a limit, no number; the forecaster's own chance of this, stated with the estimate: 50%; middle value at least 1.4-fold (0.15 log units) from the limit.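

In this assay the value of compound 4 is a limit of the assay and not a number: the limit of > 100 ug/mL in this assay, at which 1 of the 4 values shown sits. Even with that limit, this aromatic carbon accepts a sulfur-attached (4-hydroxyphenyl)sulfanyl in place of the nitrogen-attached rings, and the exchange reads as a number no lower from compound 1 to compound 4 (the limit leaves the size open) and as a number no lower from compound 2 to compound 4 (the limit leaves the size open), so the earlier agreement between the pyrrolyl and indolyl compounds now extends to a group of a different kind with no fall in the read-out. The steps that reach compound 3 cannot be read, including the exchange of cyano for (4-hydroxyphenyl)sulfanyl, and compound 3 also stands as a limit: the limit of >= 20 ug/mL in this assay, at which 1 of the 4 values shown sits.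

The compounds shown leave open how far the true value of compound 4 lies beyond its limit and whether cyano differs at all from the aromatic groups at this carbon. A phenylsulfanyl without the hydroxyl, the same ring carrying an amine or a carboxylic acid, or a longer alkyl chain on the sulfur would separate the role of the ring from that of its hydroxyl in this read-out.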